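Methoxy for trifluoromethyl on the aryl ring of compound 1

The source may report more compounds than this note shows. Statements on the series, on what has been measured and on what is new or still open speak of the compounds shown alone.

Compound 1 `CCCCCc1c(C(C)C)nc(C(C)C)c(CO)c1-c1ccc(C(F)(F)F)cc1` and compound 2 `CCCCCc1c(C(C)C)nc(C(C)C)c(CO)c1-c1ccc2c(c1)CCCC2` share one core and differ only in the aryl ring carried on it. In an assay on CHO cells for inhibition of Glucagon receptor (Homo sapiens), tested at 20 uM (on this read-out higher numbers stand for more inhibition at the one concentration tested (going by the name of the read-out) and lower numbers for less inhibition), compound 1 gives 35%, and compound 2 gives 37%. Compound 1 holds the lower of the two numbers, but the gap to compound 2 lies within the scatter of the read-out, so the two cannot be told apart on these data. Compound 3 `CCCCCc1c(C(C)C)nc(C(C)C)c(CO)c1-c1ccc(OC)cc1` has not been measured yet. It differs from compound 1 by methoxy in place of trifluoromethyl on an aromatic carbon. Going by the values given here, no step between measured compounds bears on this change, so its direction is not fixed by anything seen so far; a small step in this assay in either direction, or none beyond the scatter, is expected. Compound 3 is estimated at 30%, with a range from 10% to 50%. The step of a number 5 percentage points lower from compound 1 to compound 3 (within the scatter) is expected to stay modest.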

Compound 3, a percentage reported as inhibition, at one concentration (the size of the read-out at that concentration, not a potency): 37%
The estimate for compound 3 lay 7 percentage points below the measured number, and the stated range covers the measured number.
By their numbers in this assay, from the lowest: compounds 1, 2 and 3 (each within the scatter of the next).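

Methoxy in place of trifluoromethyl on an aromatic carbon, para to a large group, gives a number 2 percentage points higher from compound 1 to compound 3 (within the scatter) in this assay, the first step in the series that can be read at this position. Exchanging trifluoromethyl, with 4 heavy atoms and 0 hydrogen-bond acceptors, for methoxy, with 2 heavy atoms and 1 hydrogen-bond acceptor, therefore leaves no difference that can be told apart from the scatter. Nothing available explains this outcome.

The compounds shown leave open whether an amine, a carboxylic acid or a longer alkoxy chain on this aromatic carbon would move the read-out beyond the scatter. Because each number comes from one concentration, they also leave open whether compound 1 and compound 3 differ in potency.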